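The source may hold more compounds than are shown below. What is called first, only, known or untested is meant among the compounds shown, and "the series" means these compounds.

Compound 1 `Cc1cccc(Cn2cc(COc3ccc4c(=O)ccoc4c3)nn2)c1`: in a functional assay on SGC-7901 cells (Homo sapiens) for cytotoxicity, read by MTT assay, with a stated time of 48 h (on this read-out higher numbers stand for weaker inhibition and lower numbers for stronger inhibition), compound 1 gives only the assay limit, > 100000 nM.
Compound 2 `N#Cc1ccc(Cn2cc(COc3ccc4c(=O)ccoc4c3)nn2)cc1`: in this assay compound 2 likewise gives only the limit, > 100000 nM.
Compound 3 `O=c1ccoc2cc(OCc3cn(Cc4ccc([N+](=O)[O-])cc4)nn3)ccc12`: in this assay compound 3 also gives only the limit, > 100000 nM.

Compound 1 therefore stands at the limit, and every value shown sits there (the limit of > 100000 nM in this assay, at which 3 of the 3 values shown sit). Compound 4 `O=c1ccoc2cc(OCc3cn(Cc4cccc(Br)c4)nn3)ccc12` differs from compound 1 by bromo in place of methyl on an aromatic carbon. Among the measured compounds shown here, the steps that bear on changing this benzyl substituent are a step that the two limits leave unreadable from compound 1 to compound 2, a step that the two limits leave unreadable from compound 1 to compound 3 and a step that the two limits leave unreadable from compound 2 to compound 3; each runs between two limits, so none has a readable size, and no step beyond the scatter can be expected here. Compound 4 is thus expected to give about 150000 nM, most likely again only a limit, within 50000 nM to 500000 nM. The expected step is a step that the limit leaves unreadable from compound 1 to compound 4.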

Compound 4, half-maximal inhibitory concentration: > 100000 nM
Compound 4 ended at the assay's limit; the forecaster's own chance of this, stated with the estimate: 85%; the middle value does not contradict the limit.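

No new step can be read for compound 4: its comparisons with compound 1, compound 2 and compound 3 all run between two limits. How these four benzyl substituents rank against one another stays open, with every result only a limit: the limit of > 100000 nM in this assay, at which 4 of the 4 values shown sit.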